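Adding a ring methyl to compound 1

This account rests on a few compounds, and the source may have more. Where it says the series, first, only, none or still open, it means among the compounds named here.

In an ADME assay on microsomes from liver (Mus musculus) for metabolic stability, read by LC-MS, with a stated time of 30 min, tested at 1 uM (on this read-out higher numbers stand for a more stable compound and lower numbers for a less stable compound), compound 1 `CC[C@@H]1CC[C@@H](C(=O)N2CCN(C(C)=O)CC2)N1C(=O)C1=C(C(C)C)N2C(=N[C@@](C)(c3ccc(Cl)cc3)[C@H]2c2ccc(Cl)cc2)S1` gives 38% and is the lowest of the three measured compounds. Compound 2 `CC(=O)N1CCN(C(=O)[C@@H]2CC[C@@H](C)N2C(=O)C2=C(C(C)C)N3C(=N[C@@](C)(c4ccc(Cl)cc4)[C@H]3c3ccc(Cl)cc3)S2)C[C@@H]1C` stands higher at 65% and compound 3 `CC(C)C1=C(C(=O)N2[C@H](C)CC[C@H]2C(=O)N2CCN(C)C(C)(C)C2)SC2=N[C@@](C)(c3ccc(Cl)cc3)[C@@H](c3ccc(Cl)cc3)N21` stands higher again at 84% with both gaps to compound 1 beyond the scatter.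

Compound 4 `CC[C@@H]1CC[C@@H](C(=O)N2CCN(C(C)=O)[C@H](C)C2)N1C(=O)C1=C(C(C)C)N2C(=N[C@@](C)(c3ccc(Cl)cc3)[C@H]2c2ccc(Cl)cc2)S1` differs from compound 1 by methyl in place of hydrogen on a saturated ring carbon and nothing else. This is methyl in place of hydrogen on a saturated ring carbon, next to the ring atom that bears an acetyl group.

Among the compounds with values here, no measured step isolates this change. Within the data shown here, the only single-place step, a number 19 percentage points higher from compound 2 to compound 3 (beyond the scatter), swaps a whole ring group on a carbonyl carbon and bears on the case only loosely: the read-out can move beyond the scatter when that group is altered. Compound 2 also carries a methyl on a saturated ring carbon of its acetyl-bearing ring, but it differs from compound 1 elsewhere too, so the value of compound 2 at 65% does not give the size of this step.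

A modest rise is expected, estimated as a number 12 percentage points higher from compound 1 to compound 4 (beyond the scatter) with wide uncertainty. For compound 4 the estimated value is 50% (expected range 33% to 70%).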

Compound 4, percent of the compound remaining: 59%
The estimate for compound 4 lay 9 percentage points below the measured number; measured number inside the range.
By their numbers in this assay, from the lowest: compound 1; then compounds 4 and 2 (each within the scatter of the next); then compound 3.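

In this assay, methyl in place of hydrogen on a saturated ring carbon, next to the ring atom that bears an acetyl group, gives a number 21 percentage points higher from compound 1 to compound 4 (beyond the scatter). Within the data shown here, this is the first isolated reading of the change: with the rest of compound 1 held constant, this one methyl moves the read-out beyond the scatter, which the single-place step among the earlier compounds, a swap of a whole ring group, could not show. Nothing available explains the rise, and the result rests on this one matched pair.

Still open, from the compounds shown here alone, is how a hydroxymethyl group or a fluorine atom on this same carbon would read, and how a methyl with the opposite spatial arrangement at this carbon would compare. Also open, going by these compounds, is whether the step carries over to compounds with another group in place of the acetyl group, such as a methanesulfonyl group, or with another substituent in place of the ethyl group on the shared five-membered part of compound 1.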